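Methylsulfanyl in Place of Chloro on the Shared Core

The source may report more compounds than this note shows. Statements on the series, on what has been measured and on what is new or still open speak of the compounds shown alone.

Compound 1 `COc1cc(C)nc2n/c(=N/C(=O)c3c(-c4ccc(Cl)cc4Cl)noc3C)sn12`: in a functional assay on the whole organism (strain L.) for inhibition, with Echinochloa crus-galli as the target, with a stated time of 72 h, tested at 10 mg/L (a lower number here means less inhibition of growth, a higher number more inhibition of growth at the concentration tested), compound 1 gives 30.9%.
Compound 2 `COc1cc(Cl)nc2n/c(=N/C(=O)c3c(-c4ccc(Cl)cc4Cl)noc3C)sn12`: compound 2 gives 10.8%.

Among the measured compounds shown here, compound 2 stands lowest of the two numbers; the only measured step, a number 20.1 percentage points lower from compound 1 to compound 2 (beyond the scatter), arrived at it. Compound 3 `COc1cc(SC)nc2n/c(=N/C(=O)c3c(-c4ccc(Cl)cc4Cl)noc3C)sn12` differs from compound 2 by methylsulfanyl in place of chloro on an aromatic carbon. For the measured compounds named here, no measured step puts methylsulfanyl at this carbon, so the one step at this position is the sole guide, and it was modest. Compound 3 is therefore expected to move upward only a little, with wide uncertainty, estimated at 20% within 5% to 42%, a step of a number 9.2 percentage points higher from compound 2 to compound 3 (within the scatter).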

Compound 3, percent growth inhibition at one concentration: 21.4%
The estimate for compound 3 lay 1.4 percentage points below the measured number, and the stated range covers the measured number.
By their numbers in this assay, from the lowest: compound 2; then compounds 3 and 1 (each within the scatter of the next).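

In this assay, with a number 10.6 percentage points higher from compound 2 to compound 3 (beyond the scatter) methylsulfanyl at this carbon recovers part of the growth inhibition lost with chloro. With a number 9.5 percentage points lower from compound 1 to compound 3 (within the scatter) methylsulfanyl and methyl cannot be told apart here, so among the three groups only chloro stands apart at this position. Nothing at hand gives a reason for this.

Going by these compounds, whether an amine, a hydroxyl group or a longer chain such as ethylsulfanyl at this carbon would go beyond methyl and methylsulfanyl remains open. So does whether chloro stands apart in the same way on other cores.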